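A few compounds are considered here, and "the series" means these few. Any claim that something is new, unique, unknown or untested is made for them only; others in the source may bear on it.

Compound 1 `COc1cc(N)c(Cl)cc1C(=O)NC1CCNCC1` and compound 2 `COc1cc(N)c(Cl)cc1C(=O)NC1CCN(CCCCCO)CC1` share one core and differ by 5-hydroxypentyl in place of hydrogen on an amine nitrogen in a ring. In a functional assay on HEK293 cells for activation of 5-hydroxytryptamine receptor 4 (Homo sapiens), read by cAMP accumulation (a higher number here means a larger maximal response, a lower number a smaller maximal response), compound 1 reaches > 100%, a limit of the assay and not a number. In this assay compound 2 reaches > 100%, again a limit rather than a number. The step that the two limits leave unreadable from compound 1 to compound 2 is therefore unreadable in size, since both values sit at the limit of > 100% in this assay, at which 2 of the 2 values shown sit. Compound 2 thus stands at the limit, with no number to place it. Compound 3 `COc1cc(N)c(Cl)cc1C(=O)NC1CCN(CCCCCCCCO)CC1` carries the change (3-hydroxypropyl in place of hydroxy on a saturated chain carbon, five bonds along the chain from an amine nitrogen in a ring), a lengthening of the same chain. For the measured compounds named here, the only measured step bears on this change and left the maximal response at the limit, so in this assay no step beyond the scatter is expected. The step expected is a number no higher from compound 2 to compound 3 (the limit leaves the size open), none beyond the scatter. Compound 3 is expected to give 100%, between 85% and 115%, most likely again only as a limit.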

Compound 3, intrinsic activity: the largest response reached, in percent of the reference agonist's: > 100%
Compound 3 ended at the assay's limit (the forecaster's own chance of this, stated with the estimate: 70%); the middle value lies on the limit itself.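

No step can be read among compound 1, compound 2 and compound 3 in this assay, since all three values are limits of the assay and not numbers: the limit of > 100% in this assay, at which 3 of the 3 values shown sit. The compounds shown leave open whether the maximal response differs at all between hydrogen, 5-hydroxypentyl and 8-hydroxyoctyl on the amine nitrogen in the ring.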